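Adding a second hydroxy to compound 1

The source may hold more compounds than are shown below. What is called first, only, known or untested is meant among the compounds shown, and "the series" means these compounds.

Measured so far:
compound 1 `O=c1cc(-c2ccccc2)sc2ccc(O)cc12` gives 0.55 ug/mL
compound 2 `COc1cc2sc(-c3ccccc3)cc(=O)c2cc1OC` gives 8.89 ug/mL

Going by the values given here, both values come from a functional assay on RPMI cells (Homo sapiens) (on this read-out lower numbers stand for an effect already at smaller amounts and higher numbers for an effect only at larger amounts of compound), and they are the only two numbers available for the series. Compound 1 holds the lower number of the pair, and compound 2 lies above it by a gap beyond the usual scatter. The next compound to be read is compound 3 `O=c1cc(-c2ccccc2)sc2cc(O)c(O)cc12` which differs from compound 1 at a single place: hydroxy in place of hydrogen on an aromatic carbon with hydroxy in place of hydrogen on an aromatic carbon, ortho to a hydroxy group. Among the compounds with values here, no measured pair shows this change, so its size cannot be read from the data. The expectation therefore starts from compound 1 at 0.55 ug/mL and allows for a wide range on both sides. An estimated 1.6-fold higher number from compound 1 to compound 3 (0.21 log units; within the scatter) is expected to stay within the usual scatter, with a slight lean toward a higher number. In this assay the estimate for compound 3 is 0.9 ug/mL (expected range 0.2 ug/mL to 4 ug/mL).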

Compound 3, concentration for half-maximal effect: 3.92 ug/mL
The estimate for compound 3 lay 4.4-fold (0.64 log units) below the measured number; measured number inside the range.
By their numbers in this assay, from the lowest: compound 1; then compound 3; then compound 2.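

In this assay the place ortho to a hydroxy group, meta to a fused ring and para to a fused ring now has a single-change reading: hydroxy in place of hydrogen on this aromatic carbon gives a 7.1-fold higher number from compound 1 to compound 3 (0.85 log units; beyond the scatter) and so shows that the read-out responds to a change at this position. The step is beyond the usual scatter and points toward a higher number, so on the core of compound 1 a second hydroxy at this place does not bring an effect at smaller amounts. Nothing available bears on the reason for this step, which remains unassigned.

As far as these compounds go, it remains open whether the higher number goes with hydroxy specifically or with any group at this place, which an amine, a fluorine atom or a carboxylic acid in place of the hydrogen would help to separate. Also open, from the compounds shown here alone, is whether hydroxy at this place would give a step of similar size and direction on a core without the hydroxy already present in compound 1.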